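This account rests on a few compounds, and the source may have more. Where it says the series, first, only, none or still open, it means among the compounds named here.

Working notes on the series. Compound 3 `COc1ccc(-n2nc(C(=O)Nc3ccc(Oc4ccnc5cc(OCCCN6CCCC6)c(OC)cc45)c(F)c3)c(C)cc2=O)cc1` gives 3610 nM in a functional assay on NCI-H460 cells (Homo sapiens) for inhibition, read by MTT assay, with a stated time of 72 h; a higher number here means a weaker inhibitor, a lower number a stronger inhibitor. Compound 1 `COc1cc2c(Oc3ccc(NC(=O)c4nn(-c5ccccc5C)c(=O)cc4C)cc3F)ccnc2cc1OCCCN1CCC(C)CC1` gives 2260 nM in this assay, and the two values lie within the usual scatter of each other. Compound 2 `COc1cc2c(Oc3ccc(NC(=O)c4nn(-c5ccccc5OC(F)(F)F)c(=O)cc4C)cc3F)ccnc2cc1OCCCN1CCC(C)CC1` gives 290 nM in this assay, a lower number than compound 3 by more than the scatter. Within the data shown here, the only measured one-place step, a 7.8-fold lower number from compound 1 to compound 2 (0.89 log units; beyond the scatter), concerns a substituent on an aromatic carbon, elsewhere in the molecule than the change now considered. Compound 4 `COc1ccc(-n2nc(C(=O)Nc3ccc(Oc4ccnc5cc(OCCCN6CCC(C)CC6)c(OC)cc45)c(F)c3)c(C)cc2=O)cc1` differs from compound 3 by 4-methylpiperidin-1-yl in place of pyrrolidin-1-yl on a saturated chain carbon, three bonds along the chain from an oxygen on an aromatic ring. Among the measured compounds shown here, compound 1 and compound 2 both carry the 4-methylpiperidin-1-yl group, but neither forms a one-place pair with compound 3 or compound 4, so no measured step bears directly on this exchange. With nothing in the data speaking to it, the expected step is none beyond the scatter, a 1.2-fold lower number from compound 3 to compound 4 (0.08 log units; within the scatter). Compound 4 is therefore estimated at 3000 nM in this assay, with a range from 1200 nM to 8000 nM.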

Compound 4, half-maximal inhibitory concentration: 4650 nM
Beside the measured number, compound 4's estimate is 1.6-fold (0.19 log units) below it; the measured number falls inside the stated range.
By their numbers in this assay, from the lowest: compound 2; then compounds 1, 3 and 4 (each within the scatter of the next, the first and the last beyond it).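

In this assay, among these compounds, 4-methylpiperidin-1-yl in place of pyrrolidin-1-yl on the saturated chain carbon gives a 1.3-fold higher number from compound 3 to compound 4 (0.11 log units; within the scatter) and so opens no difference beyond the scatter, the first reading at this position. With 4-methylpiperidin-1-yl held constant, the group on the aromatic nitrogen matters more: 4-methoxyphenyl in place of 2-(trifluoromethoxy)phenyl gives a 16-fold higher number from compound 2 to compound 4 (1.21 log units; beyond the scatter), while 4-methoxyphenyl in place of 2-methylphenyl gives a 2.1-fold higher number from compound 1 to compound 4 (0.31 log units; beyond the scatter) as a smaller step. No measurement at hand accounts for these steps.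

Going by these compounds, it remains open whether the amine exchange would read the same with 2-(trifluoromethoxy)phenyl on the aromatic nitrogen. Also open, on these data alone, is how morpholin-4-yl or dimethylamino in place of 4-methylpiperidin-1-yl, or a longer chain than the propyl one, would read in this assay on this series.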